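The source may report more compounds than this note shows. Statements on the series, on what has been measured and on what is new or still open speak of the compounds shown alone.

Measured compounds:
compound 1, `Oc1ccc(-c2cc(-c3ccc(Cl)cc3)nc(-c3cccnc3)c2)cc1`, gives 27500 nM in an ADME assay on HEK293 cells (Homo sapiens) for cytotoxicity, read by CCK-8 assay and cell counting, with a stated time of 2 days; on this read-out higher numbers stand for weaker inhibition and lower numbers for stronger inhibition
compound 2, `Oc1ccc(-c2cc(-c3ccc(Cl)cc3)nc(-c3ccsc3)c2)cc1`, gives 4860 nM in this assay
compound 3, `Oc1cccc(-c2cc(-c3ccc(Cl)cc3)nc(-c3ccco3)c2)c1`, gives 8190 nM in this assay

Among these three numbers, compound 3 stands second highest. Its nearest neighbour is compound 2, whose number lies within the scatter of repeated measurements, so the two cannot be told apart. Compound 1 lies furthest away, with a higher number that is beyond the scatter.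

Compound 4, `Oc1ccc(-c2cc(-c3ccc(Cl)cc3)nc(-c3ccco3)c2)cc1`, has not yet been measured. It differs from compound 3 in one place: 4-hydroxyphenyl in place of 3-hydroxyphenyl on an aromatic carbon. Among the measured compounds shown here, the only measured step, a 5.7-fold lower number from compound 1 to compound 2 (0.75 log units; beyond the scatter), changes a different group on the shared core and therefore does not bear on this change. For the measured compounds named here, no measured pair shows what moving the hydroxyl on the hydroxyphenyl group does while the furan-2-yl group is kept. With no guidance in either direction, the step is expected to stay within the scatter, that is a 1.3-fold lower number from compound 3 to compound 4 (0.10 log units; within the scatter). Compound 4 is therefore estimated at 6500 nM, within a range from 2500 nM to 20000 nM.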

Compound 4, half-maximal inhibitory concentration: 5720 nM
Compound 4: middle estimate off by 1.1-fold (0.06 log units), on the high side; measured number inside the range.
By their numbers in this assay, from the lowest: compounds 2, 4 and 3 (each within the scatter of the next); then compound 1.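

With the furan-2-yl group kept, moving the hydroxyl from 3-hydroxyphenyl to 4-hydroxyphenyl gives a 1.4-fold lower number from compound 3 to compound 4 (0.16 log units; within the scatter) in this assay so the two placements at this position on the shared core cannot be told apart. With 4-hydroxyphenyl kept, furan-2-yl and thiophen-3-yl also cannot be told apart, at a 1.2-fold higher number from compound 2 to compound 4 (0.07 log units; within the scatter) while furan-2-yl in place of pyridin-3-yl gives a 4.8-fold lower number from compound 1 to compound 4 (0.68 log units; beyond the scatter) and so, of these three groups, only pyridin-3-yl stands apart. No measurement is available that would explain either result.

From the compounds shown here alone, whether swapping the hydroxyl for a methoxy group or an amine would shift the number remains open. Going by these compounds, it is also open whether the two hydroxyl placements would still match alongside pyridin-3-yl, and how a piperidine ring would compare with furan-2-yl.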